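Benzothiazole thioacetamides on a trimethoxyphenyl amide: a benzyl swap

This account rests on a few compounds, and the source may have more. Where it says the series, first, only, none or still open, it means among the compounds named here.

Measured compounds:
compound 1 `COc1ccc2nc(SCC(=O)N(Cc3ccc(OC)c(O)c3)c3cc(OC)c(OC)c(OC)c3)sc2c1` 352 nM
compound 2 `COc1ccc(CN(C(=O)CSc2nc3ccccc3s2)c2cc(OC)c(OC)c(OC)c2)cc1N` 491 nM
compound 3 `COc1ccc(CN(C(=O)CSc2nc3cc(Cl)ccc3s2)c2cc(OC)c(OC)c(OC)c2)cc1O` 429 nM

In a functional assay on HCT-116 cells (Homo sapiens) for antiproliferative activity, read by MTT assay, with a stated time of 48 h (a lower number here means a stronger inhibitor, a higher number a weaker inhibitor), compound 2 gives the highest of the three numbers, though its gaps to compound 3 and to compound 1 both lie within the scatter, so no order among them can be claimed. Compound 4 `COc1cc(N(Cc2ccc(Cl)cc2)C(=O)CSc2nc3ccccc3s2)cc(OC)c1OC` differs from compound 2 in one place: 4-chlorophenyl in place of 3-amino-4-methoxyphenyl on a saturated chain carbon bound to an amide-type nitrogen. For the measured compounds named here, the only measured step, a 1.2-fold higher number from compound 1 to compound 3 (0.09 log units; within the scatter), changes the group on sulfur, not the benzyl, and bears only loosely on this change. Going by the values given here, no measured pair varies the benzyl beyond the hydroxyl-to-amino contrast between compound 3 and compound 2, whose values lie within the scatter. A step beyond the scatter is therefore not firmly expected; compound 4 is estimated at 700 nM, between 250 nM and 2000 nM, an expected step of a 1.4-fold higher number from compound 2 to compound 4 (0.15 log units; within the scatter).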

Compound 4, half-maximal inhibitory concentration: 603000 nM
Estimate against measurement, compound 4: 860-fold (2.94 log units) below; measured number outside the range, above it.
By their numbers in this assay, from the lowest: compounds 1, 3 and 2 (each within the scatter of the next); then compound 4.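

In this assay, the benzyl on the amide-type nitrogen proves to be a position where one change has a very large effect: 4-chlorobenzyl in place of 3-amino-4-methoxybenzyl gives a 1200-fold higher number from compound 2 to compound 4 (3.09 log units; beyond the scatter). The earlier compounds showed no such step, as their only listed step changed the group on sulfur and stayed within the scatter. Nothing available accounts for the size of this step.

The amino group and the methoxy group leave together as the chlorine enters, so the step cannot be assigned to any one of them. An unsubstituted benzyl, or a benzyl carrying only the methoxy group, would be needed to separate these contributions.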